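Compound 2 to compound 3: chloro in place of fluoro

This account rests on a few compounds, and the source may have more. Where it says the series, first, only, none or still open, it means among the compounds named here.

In a functional assay on 786-0 cells (Homo sapiens) for inhibition, read by sulforhodamine B assay, with a stated time of 48 h (on this read-out lower numbers stand for stronger inhibition of growth and higher numbers for weaker inhibition of growth), compound 1 `CCOC(=O)c1nn(-c2ccc(Cl)cc2)c(-c2ccc(Cl)cc2)c1CNC(C)(C)C` gives 73700 nM; > 519000 nM (2 entries), a set of entries that offers no single number. One of these entries is a limit of the assay. Going by the values given here, compound 2 `CC(C)(C)NCc1c(C(=O)O)nn(-c2ccc(Cl)cc2)c1-c1ccc(F)cc1` gives 204000 nM, the only single number, and one further entry for this compound carries no single number. Compound 3 `CC(C)(C)NCc1c(C(=O)O)nn(-c2ccc(Cl)cc2)c1-c1ccc(Cl)cc1` carries chloro in place of fluoro on an aromatic carbon, para to a large group, the change from 4-fluorophenyl to 4-chlorophenyl: chloro in place of fluoro on an aromatic carbon. Among the compounds with values here, no measured step isolates a change at this place, so the expectation rests on compound 2 at 204000 nM. In this assay no change beyond the usual scatter is expected, and no direction is favoured. The estimated 1.2-fold lower number from compound 2 to compound 3 (0.08 log units; within the scatter) stays within that scatter. For compound 3 the expected value is 170000 nM, with an estimated range of 70000 nM to 420000 nM.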

Compound 3, concentration for 50% growth inhibition: > 599000 nM
Compound 3: only a limit was reported; the forecaster's own chance of this, stated with the estimate: 30%; middle value at least 3.5-fold (0.54 log units) away from the limit.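

In this assay, this position now has its first measured step: an at least 2.9-fold higher number from compound 2 to compound 3 (0.46 log units; beyond the scatter). Chloro in place of fluoro on an aromatic carbon, para to a large group, therefore moves the read-out towards weaker inhibition of growth by more than the scatter. Compound 3 gives > 599000 nM, which is a limit and not a number, so the direction of the step is firm while its full size stays open: the limit of > 599000 nM in this assay, at which 1 of the 3 values shown sits.

The compounds shown leave open how a methoxy group, a methyl group or a plain hydrogen at this place would read, so two halogens define no trend. The ethyl ester of compound 1 also gives no single number for comparison with the carboxylic acid of compound 3: the several entries of compound 1 in this assay, 73700 nM; > 519000 nM (2 entries)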